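Inversion of one chain stereocentre, permeability expectation

This account rests on a few compounds, and the source may have more. Where it says the series, first, only, none or still open, it means among the compounds named here.

Compound 1, `COC(c1cc(Cl)c2c(c1Cl)C(=O)N(Cc1c(C)cc(C)[nH]c1=O)CC2)C1CCOCC1`, has been run more than once in an ADME assay on MDCK cells (Canis lupus familiaris) for permeability, read by LC-MS, with a stated time of 90 min, tested at 2 uM (a higher number here means that the compound crosses the layer faster, a lower number that the compound crosses the layer more slowly), where compound 1 gives 13.3 10^-6 cm/s; 16.5 10^-6 cm/s (2 entries); the spread of its repeats, (the several entries of compound 1 in this assay, 13.3 10^-6 cm/s; 16.5 10^-6 cm/s (2 entries)), gives a sense of how far two readings of the same compound can sit apart. Compound 2, `Cc1cc(C)c(CN2CCc3c(Cl)cc([C@H](CO)[C@@H]4CCCO4)c(Cl)c3C2=O)c(=O)[nH]1`, has in this assay a single number, 14.6 10^-6 cm/s, and one further entry that reports no number. The readings of compound 1 and compound 2 sit close together, and nothing in them separates the two compounds.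

Compound 3, `Cc1cc(C)c(CN2CCc3c(Cl)cc([C@@H](CO)[C@@H]4CCCO4)c(Cl)c3C2=O)c(=O)[nH]1`, is the next member. Its relation to compound 2 is the two compounds have the same atoms and bonds and differ only in configuration as drawn: 1 of 2 stereo elements differ; a stereocentre at a saturated chain carbon is drawn R in compound 2 and S in compound 3. Among the compounds with values here, no step of this kind, a change of configuration alone, has yet been measured, so there is no measured pair to lean on.

With no evidence on either side, compound 3 is expected to stay close to compound 2, the estimated step being no change at the digits printed from compound 2 to compound 3 (within the scatter), with no particular direction and nothing beyond the usual scatter. For compound 3 in this assay the estimate is 14.6 10^-6 cm/s, within a range of 8 10^-6 cm/s to 26 10^-6 cm/s.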

Compound 3, apparent permeability: 4.3 10^-6 cm/s
For compound 3 the middle estimate is 3.4-fold (0.53 log units) above the measured one; measured number below the stated range.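

In this assay the series now holds its first measured change of configuration alone, and that change is not neutral at this chain carbon: a 3.4-fold lower number from compound 2 to compound 3 (0.53 log units; beyond the scatter). With atoms and bonds held constant, a single inversion at this position is enough to give a step beyond the scatter, so configuration here has to be tracked as a variable in its own right, and the two stereoisomers cannot be treated as interchangeable in this assay. The step can be placed at this one stereocentre, with the other stereo element drawn the same in both compounds, because nothing else separates the two structures: the fact that compounds 2 and 3 differ only in the configuration as drawn.

This remains a single pair at a single centre, so the compounds shown do not tell whether inverting the other stereo element would give a step of similar size, or what mechanism lies behind the direction of this one. From the compounds shown here alone, it is also open whether the same inversion would matter to the same degree if the hydroxyl at the end of the chain gave way to an amine or a carboxylic acid.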